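Dichloro substitution on a pyrazoline: an expected step

The source may hold more compounds than are shown below. What is called first, only, known or untested is meant among the compounds shown, and "the series" means these compounds.

Of the compounds shown here, two of a shared core have been measured in a functional assay on PC-3 cells (Homo sapiens) for cytotoxicity, read by sulforhodamine B assay, with a stated time of 48 h; on this read-out lower numbers stand for stronger inhibition and higher numbers for weaker inhibition. Compound 1 `CC(=O)N1N=C(c2ccco2)CC1c1ccc(N(C)C)cc1` gives 16700 nM in this assay. Compound 2 `CC(=O)N1N=C(c2cccc3ccccc23)CC1c1ccccc1` gives 8460 nM in this assay, the lower of the two numbers, though its gap to compound 1 lies within the scatter. Compound 3 `CC(=O)N1N=C(c2cccc3ccccc23)CC1c1cccc(Cl)c1Cl` has not been measured; it differs from compound 2 by 2,3-dichlorophenyl in place of phenyl on a saturated ring carbon. Going by the values given here, with no measured step of this kind available, a modest move toward a lower number is expected. Compound 3 is estimated at 4500 nM in this assay, between 1500 nM and 14000 nM. The expected step from compound 2 to compound 3 is a 1.9-fold lower number from compound 2 to compound 3 (0.27 log units; within the scatter).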

Compound 3, half-maximal inhibitory concentration: 20100 nM
For compound 3 the middle estimate is 4.5-fold (0.65 log units) below the measured one, outside the stated range (above it).
By their numbers in this assay, from the lowest: compounds 2, 1 and 3 (each within the scatter of the next, the first and the last beyond it).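

In this assay, going by these compounds alone, 2,3-dichlorophenyl in place of phenyl on a saturated ring carbon gives a 2.4-fold higher number from compound 2 to compound 3 (0.38 log units; beyond the scatter) and provides the first single-place comparison at this position. The change moves the number upward, so adding the two chlorine atoms to this phenyl goes with weaker inhibition in this pair. Nothing measured here accounts for the step. Still open, as far as these compounds go, is whether a single chlorine on this phenyl would also weaken inhibition. Also open, from the compounds shown here alone, is how a methoxy or hydroxyl group on this phenyl would compare.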